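Thiocarbamates on MT4 Cells: Methyl to Isopropyl

The source may report more compounds than this note shows. Statements on the series, on what has been measured and on what is new or still open speak of the compounds shown alone.

Compound 1 `S=C(Nc1cccc(Cl)c1)OCCc1ccccn1` gives 47000 nM in an ADME assay on MT4 cells (Homo sapiens) for cytotoxicity, read by MTT assay; a lower number here means that less compound is tolerated, a higher number that more compound is tolerated.
Compound 2 `Cc1ccc(NC(=S)OCCc2ccccn2)cc1` gives 75000 nM in this assay.

Of the two numbers, compound 2 stands highest in this assay, with compound 1 nearest at a value that lies within the scatter, so the two cannot be told apart. Compound 3 `CC(C)c1ccc(NC(=S)OCCc2ccccn2)cc1` has not yet been measured; it differs from compound 2 by isopropyl in place of methyl on an aromatic carbon. Within the data shown here, no step between measured compounds covers this change, so only an expectation can be set: the change is expected to move this assay little, probably not beyond the scatter, perhaps slightly downward. The expected step is a 1.4-fold lower number from compound 2 to compound 3 (0.13 log units; within the scatter). For compound 3 the estimate in this assay is 55000 nM, within a range of 22000 nM to 130000 nM.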

Compound 3, half-maximal cytotoxic concentration: 45000 nM
Estimate against measurement, compound 3: 1.2-fold (0.09 log units) above; the range from low to high includes it.
By their numbers in this assay, from the lowest: compounds 3, 1 and 2 (each within the scatter of the next).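

In this assay isopropyl in place of methyl on an aromatic carbon, para to a large group, gives a 1.7-fold lower number from compound 2 to compound 3 (0.22 log units; within the scatter), so compound 2 and compound 3 cannot be told apart. Among these compounds, this is the first step measured at this position, and it shows that going from 1 heavy atom to 3 heavy atoms here leaves the number within the scatter. Nothing measured here offers an explanation for this result. Still open, as far as these compounds go, is whether an amine, a carboxylic acid or a longer chain at this position would move the number in this assay beyond the scatter.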